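Removing one methoxy group from compound 1

The source may report more compounds than this note shows. Statements on the series, on what has been measured and on what is new or still open speak of the compounds shown alone.

Compound 1 `COc1cc(/C(=C\c2cn(C(C)=O)c3ccc(OCc4ccccc4)cc23)C(=O)O)cc(OC)c1OC` was tested in a functional assay on KB cells (Homo sapiens) for cytotoxicity, read by MTT assay, with a stated time of 72 h; on this read-out higher numbers stand for weaker inhibition and lower numbers for stronger inhibition. For compound 1 the result is only a limit of the assay, > 100000 nM, so its true value is not known. Compound 1 thus sits at the limit of > 100000 nM in this assay, at which 1 of the 2 values shown sits. Compound 2 `CC(=O)n1cc(/C=C(/C(=O)O)c2ccccc2)c2cc(OCc3ccccc3)ccc21`, which carries a phenyl in place of the 3,4,5-trimethoxyphenyl, gives in this assay 55500 nM. That step, an at least 1.8-fold lower number from compound 1 to compound 2 (0.25 log units; that floor lies within the scatter), is the only measured one, and its floor lies within the scatter, so it offers no firm direction. Compound 3 `COc1ccc(/C(=C\c2cn(C(C)=O)c3ccc(OCc4ccccc4)cc23)C(=O)O)cc1OC` differs from compound 1 by hydrogen in place of methoxy on an aromatic carbon. Among the measured compounds shown here, with compound 1 standing at a limit and the one known step small, the change is expected to be modest, a number no higher from compound 1 to compound 3 (the limit leaves the size open). Compound 3 is therefore estimated at 100000 nM, in a range from 30000 nM to 300000 nM, and may well again be reported only as a limit.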

Compound 3, half-maximal inhibitory concentration: 96700 nM
Compound 3: the middle estimate sits 1.0-fold (0.01 log units) above what was measured, within the range that was stated.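

Compound 1 gives only a limit of the assay, > 100000 nM. Compound 3, which carries 3,4-dimethoxyphenyl in place of 3,4,5-trimethoxyphenyl, gives a measured number in this assay, but the step is an at least 1.0-fold lower number from compound 1 to compound 3 (0.01 log units; that floor lies within the scatter), so losing this methoxy group shows no firm effect. The second step, a 1.7-fold higher number from compound 2 to compound 3 (0.24 log units; within the scatter), shows that the 3,4-dimethoxyphenyl and plain phenyl compounds cannot be told apart in this assay.

From the compounds shown here alone, it remains open whether any other group at this position, such as an amine or a hydroxyl in place of the methoxy group, would move the number beyond the scatter. Going by these compounds, the true size of the step from compound 1 also stays unknown, since only a limit stands for that compound.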